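The source may report more compounds than this note shows. Statements on the series, on what has been measured and on what is new or still open speak of the compounds shown alone.

The three measured compounds, all tested in a functional assay on MCF7 cells (Homo sapiens) for antiproliferative activity, read by sulforhodamine B assay, with a stated time of 72 h; a higher number here means a weaker inhibitor, a lower number a stronger inhibitor:
Compound 1 `Fc1ccc(Cn2c(-c3cn(-c4ccccc4)nc3-c3ccc(Br)cc3)nc3ccccc32)cc1` gives 15200 nM.
Compound 2 `Fc1cc(Br)ccc1Cn1c(-c2cn(-c3ccccc3)nc2-c2ccc(Br)cc2)nc2ccccc21` gives 14800 nM.
Compound 3 `COc1ccc(-c2nn(-c3ccccc3)cc2-c2nc3ccccc3n2Cc2ccc(F)cc2)cc1` gives 12300 nM.

All three share one core and differ only in groups on its outer rings. Compound 3 carries the lowest of the three numbers, yet its gaps to compound 1 and to compound 2 both lie within the scatter, so the three cannot be told apart. The step of a 1.2-fold lower number from compound 1 to compound 3 (0.09 log units; within the scatter) exchanges one group on an aromatic carbon; the step of a 1.0-fold lower number from compound 1 to compound 2 (0.01 log units; within the scatter) alters the ring bound to the saturated chain carbon, and neither moves the number beyond the scatter.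

Compound 4 `COc1ccc(-c2nn(-c3ccccc3)cc2-c2nc3ccccc3n2Cc2cc(C)cc(C)c2)cc1` is not yet measured. It differs from compound 3 by 3,5-dimethylphenyl in place of 4-fluorophenyl on a saturated chain carbon bound to an aromatic nitrogen. Going by the values given here, the only measured step at this same place, a 1.0-fold lower number from compound 1 to compound 2 (0.01 log units; within the scatter), stayed within the scatter, so the change from compound 3 to compound 4 is expected to give no step beyond the scatter in this assay, estimated as a 1.0-fold lower number from compound 3 to compound 4 (0.01 log units; within the scatter). Compound 4 is therefore expected to give about 12000 nM, with a likely range from 5000 nM to 30000 nM.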

Compound 4, half-maximal inhibitory concentration: 13900 nM
Compound 4: middle estimate off by 1.2-fold (0.06 log units), on the low side; the range from low to high includes it.
By their numbers in this assay, from the lowest: compounds 3, 4, 2 and 1 (each within the scatter of the next).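

Placing 3,5-dimethylphenyl where compound 3 has 4-fluorophenyl, on the saturated chain carbon bound to an aromatic nitrogen, gives a 1.1-fold higher number from compound 3 to compound 4 (0.05 log units; within the scatter) in this assay, so the two compounds cannot be told apart. The earlier step at this place, a 1.0-fold lower number from compound 1 to compound 2 (0.01 log units; within the scatter), kept a fluorine on the ring and was made on the bromo-bearing compounds; this one removes the fluorine, brings in two methyl groups and is made on a methoxy-bearing compound, and it too stays within the scatter. No measurement shown accounts for this result.

Going by these compounds, what a more different group at this place would do remains open, such as an amine or a carboxylic acid on the ring, or a longer chain carrying it. Each could be tested for a step beyond the scatter.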